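This account rests on a few compounds, and the source may have more. Where it says the series, first, only, none or still open, it means among the compounds named here.

In a functional assay on MCF7 cells (Homo sapiens) for antiproliferative activity, read by MTT assay, with a stated time of 48 h (on this read-out higher numbers stand for weaker inhibition and lower numbers for stronger inhibition), compound 1 `O=C(NS(=O)(=O)c1ccccc1)c1ccc(Cl)nc1` gives 14100 nM and compound 2 `Cc1ccc(S(=O)(=O)NC(=O)c2ccc(Cl)nc2)cc1` gives 17200 nM while compound 3 `O=C(NS(=O)(=O)c1ccc(Br)cc1)c1ccc(Cl)nc1` gives 9050 nM on the same scale. Compound 3 thus stands level with the other two on these numbers. Compound 4 `O=C(NS(=O)(=O)c1ccc(Cl)cc1)c1ccc(Cl)nc1` differs from it by one swap chloro in place of bromo on an aromatic carbon that puts chloro in place of bromo on an aromatic carbon, para to a large group. Among the compounds with values here, two measured steps bear on this: bromo in place of hydrogen gave a 1.6-fold lower number from compound 1 to compound 3 (0.19 log units; within the scatter) and bromo in place of methyl gave a 1.9-fold lower number from compound 2 to compound 3 (0.28 log units; within the scatter) and neither leaves the scatter. So no step beyond the scatter is expected in this assay and the estimated step is a 1.2-fold higher number from compound 3 to compound 4 (0.06 log units; within the scatter) with no firm direction to it. For compound 4 the estimated value is 10500 nM with an expected range from 6000 nM to 18000 nM in this measurement.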

Compound 4, half-maximal inhibitory concentration: 8070 nM
Beside the measured number, compound 4's estimate is 1.3-fold (0.11 log units) above it; the measured number falls inside the stated range.
By their numbers in this assay, from the lowest: compounds 4, 3, 1 and 2 (each within the scatter of the next, the first and the last beyond it).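

Swapping bromo for chloro at this position in this assay gives a 1.1-fold lower number from compound 3 to compound 4 (0.05 log units; within the scatter) and so does not separate the two halogens. Against methyl, chloro gives a 2.1-fold lower number from compound 2 to compound 4 (0.33 log units; beyond the scatter) as the first step here to leave the scatter, though only modestly, whereas against hydrogen it gives a 1.7-fold lower number from compound 1 to compound 4 (0.24 log units; within the scatter) and no separation can be claimed. Nothing available explains these numbers. From the compounds shown here alone, whether an amine, a methoxy group or a carboxylic acid at this position would shift the number more remains open.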